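The source may hold more compounds than are shown below. What is called first, only, known or untested is meant among the compounds shown, and "the series" means these compounds.

Compound 3 `NCCCCCN(Cc1nc2ccccc2[nH]1)C1CCCc2cccnc21` gives 514 nM in a functional assay on CEM-CCRF cells for antagonist activity at C-X-C chemokine receptor type 4 (Homo sapiens), read by calcium flux (a lower number here means a stronger inhibitor, a higher number a weaker inhibitor), the second highest of the three numbers; compound 1 `NC/C=C/CN(Cc1nc2ccccc2[nH]1)C1CCCc2cccnc21` gives 160 nM and compound 2 `NCCN(Cc1nc2ccccc2[nH]1)C1CCCc2cccnc21` gives 1370 nM. Compound 4 `CN(C)CCCCN(Cc1nc2ccccc2[nH]1)C1CCCc2cccnc21` differs from compound 3 by dimethylamino in place of aminomethyl on a saturated chain carbon, four bonds along the chain from an amine nitrogen. For the measured compounds named here, no measured step changes the terminal amine in this way; the steps that bear on chain length are a 2.7-fold lower number from compound 2 to compound 3 (0.43 log units; beyond the scatter) and a 3.2-fold higher number from compound 1 to compound 3 (0.51 log units; beyond the scatter), both modest. The shortening of the chain by one carbon in compound 4 is therefore expected to cost a little, with the dimethyl substitution unaccounted for, so a modest rise of a 1.5-fold higher number from compound 3 to compound 4 (0.16 log units; within the scatter) in this assay is expected. Compound 4 is estimated at 750 nM, between 200 nM and 2800 nM.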

Compound 4, half-maximal inhibitory concentration: 87 nM
The estimate for compound 4 lay 8.6-fold (0.94 log units) above the measured number; the measured number lies below the stated range.
By their numbers in this assay, from the lowest: compounds 4 and 1 (each within the scatter of the next); then compound 3; then compound 2.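

In this assay, the chain end proves able to carry dimethylamino with a gain rather than a loss, with a 5.9-fold lower number from compound 3 to compound 4 (0.77 log units; beyond the scatter) and, the largest step in the set, a 16-fold lower number from compound 2 to compound 4 (1.20 log units; beyond the scatter). The step of a 1.8-fold lower number from compound 1 to compound 4 (0.26 log units; within the scatter) shows that a saturated 3-(dimethylamino)propyl chain reaches the level of the 3-aminoprop-1-en-1-yl chain, within the scatter. No evidence given here accounts for this gain. As far as these compounds go, since the step alters both chain and terminal amine, the share of each stays open, as does how a methylamino or pyrrolidine end group would compare.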